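Swapping the anilino halogens for a 4-ethylphenyl group

The compounds below may be only part of what the source reports. "The series", "measured", "known", "first", "only" and "open" are said of these compounds alone.

Three thioureas sharing one core have been measured in a functional assay on NCI-H1975 cells (Homo sapiens) for antiproliferative activity, read by MTT assay, with a stated time of 72 h; a lower number here means a stronger inhibitor, a higher number a weaker inhibitor. Compound 1 `NS(=O)(=O)c1ccc(NC(=S)Nc2ccc3ncnc(Nc4ccc(F)c(Cl)c4)c3c2)cc1` gives 15800 nM, compound 2 `NS(=O)(=O)c1ccc(NC(=S)Nc2ccc3ncnc(Nc4cccc(C(F)(F)F)c4)c3c2)cc1` gives 7590 nM and compound 3 `NS(=O)(=O)c1ccc(NC(=S)Nc2ccc3ncnc(Nc4cccc(Cl)c4F)c3c2)cc1` gives 25100 nM. Compound 3 has the highest of the three numbers: the step of a 1.6-fold higher number from compound 1 to compound 3 (0.20 log units; within the scatter) stays within the scatter, while the step of a 3.3-fold higher number from compound 2 to compound 3 (0.52 log units; beyond the scatter) is modest but real. The step of a 2.1-fold lower number from compound 1 to compound 2 (0.32 log units; beyond the scatter) shows that changing only the aryl group on the nitrogen on an aromatic ring moves the number by a modest amount in this set.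

Compound 4 `CCc1ccc(Nc2ncnc3ccc(NC(=S)Nc4ccc(S(N)(=O)=O)cc4)cc23)cc1` differs from compound 3 by 4-ethylphenyl in place of 3-chloro-2-fluorophenyl on a nitrogen on an aromatic ring. Within the data shown here, no measured pair involves a group without halogens, so the bearing of the existing steps is only indirect: all three show that this aryl group shifts the number within a narrow band, and none of them points to a large gain or loss. Compound 4 is therefore expected to land near compound 3, with an expected step of a 1.3-fold lower number from compound 3 to compound 4 (0.10 log units; within the scatter) that is small. The estimate for compound 4 in this assay is 20000 nM, with a range from 6000 nM to 70000 nM.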

Compound 4, half-maximal inhibitory concentration: 38700 nM
The estimate for compound 4 lay 1.9-fold (0.29 log units) below the measured number; low and high end bracket the measured number.
By their numbers in this assay, from the lowest: compound 2; then compounds 1, 3 and 4 (each within the scatter of the next, the first and the last beyond it).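

In this assay, among these compounds, compound 4 gives the first reading for an aryl group without halogen on this nitrogen, and it stays level with a halogen-bearing group (a 1.5-fold higher number from compound 3 to compound 4 (0.19 log units; within the scatter)), so halogen atoms on this ring are not required for a number in the range of compound 3. The same change does separate from the other two aryl groups (a 2.4-fold higher number from compound 1 to compound 4 (0.39 log units; beyond the scatter); a 5.1-fold higher number from compound 2 to compound 4 (0.71 log units; beyond the scatter)), the last being the widest step in the set so far, and compound 2 keeps the lowest number, with its steps to all three others beyond the scatter. No measurement offered here accounts for this order.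

From the compounds shown here alone, the ethyl group and the loss of the halogens arrive together in compound 4, as does the shift of the substituent around the ring, so the share of each in the step remains open. Going by these compounds, how an unsubstituted phenyl group, or a phenyl ring carrying an amine, a carboxylic acid or a longer chain, would stand at this place on the nitrogen also remains open.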